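The source may report more compounds than this note shows. Statements on the series, on what has been measured and on what is new or still open speak of the compounds shown alone.

Working notes on the thiazolyl semicarbazone series.

The reference point is compound 2 `CN(C)Cc1ccc2nc(NC(=O)N/N=C/c3cn(Cc4ccc(Cl)cc4)c4ccccc34)sc2c1`, which in a functional assay on NCI-H460 cells (Homo sapiens) for cytotoxicity, read by MTT assay, with a stated time of 72 h (on this read-out lower numbers stand for stronger inhibition and higher numbers for weaker inhibition), gives 290 nM. Compound 1 `CN(C)Cc1ccc2nc(NC(=O)N/N=C/c3cn(Cc4ccc(C(C)(C)C)cc4)c4ccccc34)sc2c1` differs from it only by tert-butyl in place of chloro on an aromatic carbon; in this assay compound 1 gives 810 nM, which is a 2.8-fold higher number from compound 2 to compound 1 (0.45 log units; beyond the scatter). Compound 3 `CC1CCN(Cc2ccc3nc(NC(=O)N/N=C/c4cn(Cc5ccc(Cl)cc5)c5ccccc45)sc3c2)CC1` keeps the chloro group and changes the other end of the molecule, (4-methylpiperidin-1-yl in place of dimethylamino on a saturated chain carbon bound to an aromatic carbon); in this assay compound 3 gives 400 nM, a step of a 1.4-fold higher number from compound 2 to compound 3 (0.14 log units; within the scatter), so compound 2 and compound 3 are not separated by this read-out.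

Compound 4 `CC1CCN(Cc2ccc3nc(NC(=O)N/N=C/c4cn(Cc5ccc(C(C)(C)C)cc5)c5ccccc45)sc3c2)CC1` has not yet been run in this assay. It differs from compound 3 by tert-butyl in place of chloro on an aromatic carbon. The change is the same one that was made from compound 2 to compound 1, and the two "place" descriptions match word for word, so it is the same change carried onto a different core; the two cores themselves differ only in the way already described from compound 2 to compound 3. Among the compounds with values here, only one measured instance of this change exists, which is a thin basis, but nothing in the data suggests the core change interferes with it.

Compound 4 is therefore expected to sit at a 2.8-fold higher number from compound 3 to compound 4 (0.44 log units; beyond the scatter), because the same change gave a 2.8-fold higher number from compound 2 to compound 1 (0.45 log units; beyond the scatter) and the core difference gave only a 1.4-fold higher number from compound 2 to compound 3 (0.14 log units; within the scatter). The estimate for compound 4 in this assay is 1100 nM, with a range of 550 nM to 2400 nM.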

Compound 4, half-maximal inhibitory concentration: 3370 nM
For compound 4 the middle estimate is 3.1-fold (0.49 log units) below the measured one; measured number above the stated range.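

In this assay, tert-butyl in place of chloro raises the number on both cores, but the size of the step does not carry over, and on the core of compound 3 it gives an 8.4-fold higher number from compound 3 to compound 4 (0.93 log units; beyond the scatter): the same change on two cores in this assay, a 2.8-fold higher number (0.45 log units; beyond the scatter) from compound 2 to compound 1 and an 8.4-fold higher number (0.93 log units; beyond the scatter) from compound 3 to compound 4, 3.0-fold (0.48 log units) apart, beyond the scatter of two such steps.

Read along the other edge of the same four compounds, 4-methylpiperidin-1-yl in place of dimethylamino gives a 4.2-fold higher number from compound 1 to compound 4 (0.62 log units; beyond the scatter) when tert-butyl is present, a clear step that is absent when chloro is present: the same change on two cores in this assay, a 1.4-fold higher number (0.14 log units; within the scatter) from compound 2 to compound 3 and a 4.2-fold higher number (0.62 log units; beyond the scatter) from compound 1 to compound 4, 3.0-fold (0.48 log units) apart, beyond the scatter of two such steps.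

The two changes therefore do not add independently in this set, so a step measured on one core is a poor guide to its size on the other, though this rests on a single set of four compounds and shows neither the reason for the gap nor whether it extends to other groups.

The compounds shown leave open whether the gap belongs to tert-butyl specifically or would also appear with another group at that place, such as methyl, methoxy or trifluoromethyl. As far as these compounds go, it is equally open whether it needs the 4-methyl group of the 4-methylpiperidin-1-yl amine, which an unsubstituted piperidine or a morpholine at the other end of the molecule would test.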